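The source may hold more compounds than are shown below. What is called first, only, known or untested is meant among the compounds shown, and "the series" means these compounds.

Compound 2, with the structure `COc1ccc(NC(=O)COc2cc(C)nc3ccc(OC)cc23)cc1`, was measured in a physicochemical assay for solubility, in phosphate buffer, measured as kinetic solubility, with a stated time of 1 h, at pH 7.4 (a lower number here means a less soluble compound, a higher number a more soluble compound), where it gives 108000 nM. For the measured compounds named here, that is the higher of the two numbers known here. The other measured compound, compound 1, with the structure `COc1ccc2nc(C)cc(NC(=O)C(=O)Nc3cc(C)cc(C)c3)c2c1`, gives 10000 nM in this assay, a lower number, and the gap between the two lies beyond the scatter. The two compounds differ in several places at once, so their values show only where each stands, not what any single change does.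

Compound 3, with the structure `COc1ccc2nc(C)cc(OCC(=O)Nc3nc(C)c(C)s3)c2c1`, has not yet been measured. It differs from compound 2 in one place: 4,5-dimethyl-1,3-thiazol-2-yl in place of 4-methoxyphenyl on an amide-type nitrogen. Going by the values given here, no measured pair in this set isolates such a change, so there is no step to lean on. The expectation is a modest move downward in this assay, on the order of a 2.7-fold lower number from compound 2 to compound 3 (0.43 log units; beyond the scatter), which may still fall within the scatter. On that basis compound 3 is estimated at 40000 nM, with a likely range from 10000 nM to 150000 nM.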

Compound 3, solubility: 31500 nM
The estimate for compound 3 lay 1.3-fold (0.10 log units) above the measured number; measured number inside the range.
By their numbers in this assay, from the lowest: compound 1; then compound 3; then compound 2.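

For the compounds shown here, compound 3 gives the first reading of a single change: on an amide-type nitrogen whose other neighbour is the carbonyl carbon, 4,5-dimethyl-1,3-thiazol-2-yl in place of 4-methoxyphenyl brings a 3.4-fold lower number from compound 2 to compound 3 (0.54 log units; beyond the scatter) in this assay, a modest step but one beyond the scatter. The group on this nitrogen therefore matters to the read-out, and the exchange of one aromatic ring for another leaves compound 3 at 31500 nM in the same assay. Nothing measured here accounts for the size or direction of this step.

The change replaces a six-membered ring of carbon only with a five-membered ring with 2 hetero atoms and alters the groups carried on the ring, so this one step cannot show which of these differences matters. The compounds shown leave open how a plain thiazol-2-yl without its two methyl groups or an unsubstituted phenyl would read, and whether a phenyl carrying an amine or a carboxylic acid would move the number further in either direction.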